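This account rests on a few compounds, and the source may have more. Where it says the series, first, only, none or still open, it means among the compounds named here.

In an assay on HEK293 cells for antagonist activity at Toll-like receptor 9 (Homo sapiens), read by spectrophotometry (on this read-out higher numbers stand for weaker inhibition and lower numbers for stronger inhibition), compound 1, whose structure is `CCN1CCN(CCCn2cnc3c(N4CCN(CC)CC4)nc(NCc4ccccc4)nc32)CC1`, gives 140 nM. Among the compounds with values here, of the three compounds measured so far, compound 1 shows the lowest number. Its closest neighbour is compound 3, `CCN1CCN(CCCn2cnc3c(N4CCN(CC)CC4)nc(NCc4ccc(OC)cc4)nc32)CC1`, which carries a methoxy group in place of a hydrogen on an aromatic carbon and gives 200 nM; the step of a 1.4-fold higher number from compound 1 to compound 3 (0.15 log units; within the scatter) lies within the scatter of the assay. The furthest is compound 2, `CCN1CCN(CCCn2cnc3c(N4CCN(C(=O)C5CCCC5)CC4)nc(NCc4ccc(N(CC)CC)cc4)nc32)CC1`, which differs from compound 1 in several places at once. Compound 2 gives 8800 nM; no single change can be read out of that gap.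

The compound still to be measured is compound 4, `CCN1CCN(CCCn2cnc3c(N4CCN(CC)CC4)nc(NCc4ccc(F)cc4)nc32)CC1`. It differs from compound 1 by fluoro in place of hydrogen on an aromatic carbon. Within the data shown here, only one measured step bears on this change: the one from compound 1 to compound 3, where another small group entered at an aromatic carbon and the number barely moved, as a 1.4-fold higher number from compound 1 to compound 3 (0.15 log units; within the scatter) shows. On that basis a step of no more than the scatter is expected for compound 4, in either direction, and the expected step is a 1.1-fold higher number from compound 1 to compound 4 (0.06 log units; within the scatter). The estimate for compound 4 in this assay is therefore 160 nM, with a range from 70 nM to 360 nM.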

Compound 4, half-maximal inhibitory concentration: 470 nM
Compound 4: the middle estimate sits 2.9-fold (0.47 log units) below what was measured; the measured number lies above the stated range.
By their numbers in this assay, from the lowest: compounds 1 and 3 (each within the scatter of the next); then compound 4; then compound 2.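

Fluoro in place of hydrogen on this aromatic carbon, para to a large group, gives a 3.4-fold higher number from compound 1 to compound 4 (0.53 log units; beyond the scatter) in this assay, so one added heavy atom is enough to carry the number beyond the scatter, which the methoxy step, a 1.4-fold higher number from compound 1 to compound 3 (0.15 log units; within the scatter), did not do. The two groups at this same carbon also differ from each other, with a 2.4-fold higher number from compound 3 to compound 4 (0.37 log units; beyond the scatter), so the position does not respond alike to every group placed there, and the higher number comes with fluoro rather than with methoxy. Nothing available here accounts for this difference between the two groups.

Going by these compounds, whether chloro, a hydroxyl group or a nitrile on this carbon would stay close to compound 1, as methoxy does, or move the number as fluoro does remains open. On these data alone, it is equally open whether fluoro on another carbon of the same ring would give a step of this size, and whether the step would hold if the ethyl groups on the shared core were replaced by a longer chain.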